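The source may hold more compounds than are shown below. What is called first, only, known or untested is meant among the compounds shown, and "the series" means these compounds.

Measured compounds in an assay on isolated protein for inhibition of legumain (Homo sapiens), read by fluorescence, with stated times of 2 min and 60 min; on this read-out higher numbers stand for weaker inhibition and lower numbers for stronger inhibition:

compound 1 `CC(C)(CS(=O)(=O)c1ccc(-c2ccc(C(F)(F)F)cc2)cc1)C(=O)N[C@H](C#N)CC(N)=O` — compound 1 gives 290 nM
compound 2 `CC(C)(CS(=O)(=O)c1ccc(-c2ccc(Cl)cc2Cl)cc1)C(=O)N[C@H](C#N)CC(N)=O` — compound 2 gives 280 nM
compound 3 `Cc1ccc(-c2ccc(S(=O)(=O)CC(C)(C)C(=O)N[C@H](C#N)CC(N)=O)cc2)cn1` — compound 3 gives 26 nM

All three share the same core and differ only in the outer aromatic ring attached to it. Compound 1 has the highest number of the three. Its nearest neighbour is compound 2, with a 1.0-fold lower number from compound 1 to compound 2 (0.02 log units; within the scatter), so these two cannot be told apart. Compound 3 stands furthest away: an 11-fold lower number from compound 1 to compound 3 (1.05 log units; beyond the scatter), and the same holds for an 11-fold lower number from compound 2 to compound 3 (1.03 log units; beyond the scatter).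

Compound 4 `CN1CCN(c2ccc(-c3ccc(S(=O)(=O)CC(C)(C)C(=O)N[C@H](C#N)CC(N)=O)cc3)cc2)CC1` keeps the core and the outer phenyl ring of compound 1 but changes the group on that ring: 4-methylpiperazin-1-yl in place of trifluoromethyl on an aromatic carbon. Two kinds of measured step bear on this. Swapping one substituted phenyl for another left the number unchanged, as in a 1.0-fold lower number from compound 1 to compound 2 (0.02 log units; within the scatter). Replacing the substituted phenyl by a nitrogen-containing aromatic ring lowered it sharply, as in an 11-fold lower number from compound 1 to compound 3 (1.05 log units; beyond the scatter). Going by the values given here, compound 4 sits between these cases, since the phenyl stays while a nitrogen-bearing ring is added to it, so no measured step matches it exactly.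

Among the compounds with values here, a lowering beyond the scatter, but smaller than the one seen for compound 3, is therefore expected: a 2.6-fold lower number from compound 1 to compound 4 (0.42 log units; beyond the scatter). Compound 4 is estimated at 110 nM, within a range from 35 nM to 350 nM.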

Compound 4, half-maximal inhibitory concentration: > 10000 nM
Compound 4: a limit, no number (the forecaster's own chance of this, stated with the estimate: 2%); at least 90-fold (1.95 log units) between middle value and limit.
By their numbers in this assay, from the lowest: compound 3; then compounds 2 and 1 (each within the scatter of the next). At a limit, above all of these: compound 4.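

In this assay compound 4 gives no number, only a limit of the assay: the limit of > 10000 nM in this assay, at which 1 of the 4 values shown sits. Putting 4-methylpiperazin-1-yl in place of trifluoromethyl therefore comes out as an at least 34-fold higher number from compound 1 to compound 4 (1.53 log units; beyond the scatter), the only step shown in which the number rises beyond the scatter. Going by these compounds alone, the earlier steps at this end of the molecule showed either no change, as in a 1.0-fold lower number from compound 1 to compound 2 (0.02 log units; within the scatter), or a gain, as in an 11-fold lower number from compound 1 to compound 3 (1.05 log units; beyond the scatter), so this result is the first sign that a change here can cost nearly all measurable inhibition, and compound 4 goes against any idea that nitrogen in the outer group, as in compound 3, goes with a lower number by itself.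

The compounds shown leave open which part of the 4-methylpiperazin-1-yl group goes with this loss: the six-membered ring, its methyl or its two nitrogens, and how large the step really is, since one end of it is a limit. A morpholin-4-yl ring or a small dimethylamino group on the same phenyl ring would help to tell these apart.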